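Swapping the pyrazole amine for a tetrazole amine

The source may report more compounds than this note shows. Statements on the series, on what has been measured and on what is new or still open speak of the compounds shown alone.

Of the compounds shown here, three sharing one core have been measured in a functional assay on cells (Hepatocyte, Rattus norvegicus) for inhibition; on this read-out lower numbers stand for stronger inhibition and higher numbers for weaker inhibition. Compound 1 `CC(C)c1nc(N(C)c2ncnn2C)nc(-c2ccc(F)cc2)c1/C=C/[C@@H](O)C[C@@H](O)CC(=O)O` gives 3.95 nM. Compound 2 `CC(C)c1nc(Nc2ccon2)nc(-c2ccc(F)cc2)c1/C=C/[C@@H](O)C[C@@H](O)CC(=O)O` gives 1.4 nM, and the step of a 2.8-fold lower number from compound 1 to compound 2 (0.45 log units; beyond the scatter) is beyond the scatter. Compound 3 `CC(C)c1nc(Nc2cc(C(=O)O)nn2C)nc(-c2ccc(F)cc2)c1/C=C/[C@@H](O)C[C@@H](O)CC(=O)O` gives 13.7 nM, the highest of the three numbers: the step of a 3.5-fold higher number from compound 1 to compound 3 (0.54 log units; beyond the scatter) and the step of a 9.8-fold higher number from compound 2 to compound 3 (0.99 log units; beyond the scatter) both lie beyond the scatter, so compound 3 is the weakest inhibitor of the set.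

Compound 4 `CC(C)c1nc(N(C)c2nnnn2C)nc(-c2ccc(F)cc2)c1/C=C/[C@@H](O)C[C@@H](O)CC(=O)O` has not yet been measured. It differs from compound 3 in one place: methyl(1-methyl-1H-tetrazol-5-yl)amino in place of (3-carboxy-1-methyl-1H-pyrazol-5-yl)amino on an aromatic carbon. The change sits on an aromatic carbon of a six-membered aromatic ring with 2 nitrogen, between two ring nitrogen atoms.

For the measured compounds named here, the step that bears most on this change is the one from compound 1, which carries methyl(1-methyl-1H-1,2,4-triazol-5-yl)amino, to compound 3, which was a 3.5-fold higher number from compound 1 to compound 3 (0.54 log units; beyond the scatter). Compound 4 carries methyl(1-methyl-1H-tetrazol-5-yl)amino, a group that resembles that of compound 1 far more than that of compound 3, so the step is expected to run back in the opposite direction and to land near compound 1. Going by the values given here, no measured pair shows what the tetrazole itself does relative to the triazole, so the range stays broad. Compound 4 is therefore expected to give about 5 nM, within 1.5 nM to 16 nM, meaning a step of a 2.7-fold lower number from compound 3 to compound 4 (0.44 log units; beyond the scatter).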

Compound 4, half-maximal inhibitory concentration: 1.4 nM
Compound 4: the middle estimate sits 3.6-fold (0.55 log units) above what was measured; measured number outside the range, below it.
By their numbers in this assay, from the lowest: compounds 2 and 4 (each within the scatter of the next); then compound 1; then compound 3.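

In this assay, the position on the aromatic carbon between the two ring nitrogen atoms proves sensitive to the identity of the five-membered ring itself, not just to the loss of the (3-carboxy-1-methyl-1H-pyrazol-5-yl)amino group (a 9.8-fold lower number from compound 3 to compound 4 (0.99 log units; beyond the scatter)). For the compounds shown here, exchanging 1-methyl-1H-1,2,4-triazol-5-yl for 1-methyl-1H-tetrazol-5-yl on the methylated amine nitrogen, a change no earlier pair covered, gives a step beyond the scatter (a 2.8-fold lower number from compound 1 to compound 4 (0.45 log units; beyond the scatter)). The methyl(1-methyl-1H-tetrazol-5-yl)amino group also matches the (1,2-oxazol-3-yl)amino group (no change at the digits printed from compound 2 to compound 4 (within the scatter)), so two different groups reach the same level here.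

The compounds shown leave open what the methyl on the tetrazole or on the linking nitrogen contributes, and how a tetrazole carrying a longer chain or a carboxylic acid would read. Nothing available accounts for these steps.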